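This account rests on a few compounds, and the source may have more. Where it says the series, first, only, none or still open, it means among the compounds named here.

Among the measured compounds shown here, compound 1 `CCCCCCCCCCNC[C@@H]1OC[C@H](N)[C@@H]1O` is one of two compounds so far tested in a functional assay on MCF7 cells (Homo sapiens) for antiproliferative activity, read by MTT assay, with a stated time of 72 h; a higher number here means a weaker inhibitor, a lower number a stronger inhibitor. In this assay compound 1 gives 34200 nM, the highest of the two numbers recorded, which places it as the weaker inhibitor of the pair. Compound 2 `CCCCCCCCCCCCNC[C@@H]1OC[C@H](N)[C@H]1O` carries a longer chain and a different arrangement at the hydroxyl-bearing carbon of the shared core; in this assay compound 2 gives 12600 nM, and the gap between the two compounds lies beyond the usual scatter. For the measured compounds named here, since compound 2 differs from compound 1 in two places at once, no single-change step between measured compounds can be read from this pair, and the effect of chain length alone remains untested.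

Compound 3 `CCCCCCCCCNC[C@@H]1OC[C@H](N)[C@@H]1O` is the unmeasured analogue of compound 1 with a shorter chain: hydrogen in place of methyl on a saturated chain carbon, nine bonds along the chain from an amine nitrogen. With no clean chain-length comparison available, the step is expected to be modest. The step from compound 1 to compound 3 is expected to be a 1.3-fold higher number from compound 1 to compound 3 (0.12 log units; within the scatter), toward a higher number but not clearly beyond the scatter. Compound 3 is therefore expected to give about 45000 nM in this assay, within a range from 20000 nM to 100000 nM.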

Compound 3, half-maximal inhibitory concentration: 12500 nM
Estimate against measurement, compound 3: 3.6-fold (0.56 log units) above; the measured number lies below the stated range.
By their numbers in this assay, from the lowest: compounds 3 and 2 (each within the scatter of the next); then compound 1.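

Among the compounds shown here, the change from methyl to hydrogen gives the first single-change reading on this core: in this assay, the step is a 2.7-fold lower number from compound 1 to compound 3 (0.44 log units; beyond the scatter), on a saturated chain carbon, nine bonds along the chain from an amine nitrogen. The earlier pair differed in two places at once, whereas here the arrangement at the hydroxyl-bearing carbon is held fixed, so this step shows that a change in chain length alone can move the number beyond the usual scatter, and that the shorter chain is the stronger inhibitor of these two. No measurement at hand explains why the loss of a single carbon has this effect.

One step cannot show whether the number would keep falling with a still shorter chain, such as an octyl or hexyl chain, or whether compound 3 sits near a limit of that trend. Also open, from the compounds shown here alone, are the separate contribution of the arrangement at the hydroxyl-bearing carbon, which compound 2 changes only together with its chain, and the outcome of placing a terminal hydroxyl or a phenyl group on the chain.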